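The source may report more compounds than this note shows. Statements on the series, on what has been measured and on what is new or still open speak of the compounds shown alone.

Working notes on the series. In a physicochemical assay for solubility, read by spectrophotometry, measured as kinetic solubility, at pH 8, tested at 500 uM (on this read-out lower numbers stand for lower solubility and higher numbers for higher solubility), compound 1 `Cn1cc(CNS(=O)(=O)c2ccccc2Nc2cc(-c3ccc4ccn(C)c4c3)c3nccnc3c2)cn1` gives 2 ug/mL and compound 2 `Cn1ccc2ccc(-c3cc(Nc4ccccc4S(=O)(=O)NCC4CCOCC4)cc4nccnc34)cc21` gives 2 ug/mL; the step of no change at the digits printed from compound 1 to compound 2 (within the scatter) lies within the scatter. Compound 3 `CNC(=O)c1ccncc1Nc1cc(-c2ccc3ccn(C)c3c2)c2nccnc2c1` gives 4 ug/mL in this assay, and its gaps to compound 1 and compound 2 are both within the scatter, so no order among the three can be read. Compound 4 `CC(=O)N1CC(NC(=O)c2ccncc2Nc2cc(-c3ccc4ccn(C)c4c3)c3nccnc3c2)C1` is not yet measured; it differs from compound 3 by 1-acetylazetidin-3-yl in place of methyl on an amide-type nitrogen. Within the data shown here, no measured step touches this amide-type nitrogen; the only step on record, from compound 1 to compound 2, concerned a sulfonamide nitrogen and showed no change. For compound 4 a step of a 1.5-fold higher number from compound 3 to compound 4 (0.18 log units; within the scatter) is therefore expected, at most modest and possibly within the scatter. Compound 4 is estimated at 6 ug/mL, range 2 ug/mL to 18 ug/mL.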

Compound 4, solubility: 244 ug/mL
Compound 4: the middle estimate sits 41-fold (1.61 log units) below what was measured; the measured number lies above the stated range.
By their numbers in this assay, from the lowest: compounds 1, 2 and 3 (each within the scatter of the next); then compound 4.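

At the amide-type nitrogen, 1-acetylazetidin-3-yl in place of methyl gives a 61-fold higher number from compound 3 to compound 4 (1.79 log units; beyond the scatter) in this assay. This position can therefore move the read-out far beyond the scatter, whereas compounds 1, 2 and 3 all lay within the scatter of one another. Nothing on hand explains the size of this step. Still open, as far as these compounds go, is whether the step belongs to the acetyl or to the four-membered ring, and what a free amine on that ring or a longer chain on the amide-type nitrogen would give.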